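Swapping the dichlorobenzyl for a fluorobenzyl

A few compounds are considered here, and "the series" means these few. Any claim that something is new, unique, unknown or untested is made for them only; others in the source may bear on it.

Of the compounds shown here, three sharing one core have been measured in a functional assay on SW-620 cells (Homo sapiens) for inhibition, read by MTT assay, with a stated time of 48 h; a higher number here means a weaker inhibitor, a lower number a stronger inhibitor. Compound 1 `Cc1ccc(NC(=O)NC(=O)c2ccc(OCc3ccccc3)cc2)cc1-c1nc2ccccc2[nH]1` gives 30100 nM, compound 2 `Cc1ccc(NC(=O)NC(=O)c2ccc(OCc3cccc(Cl)c3Cl)cc2)cc1-c1nc2ccccc2[nH]1` gives 42100 nM, and compound 3 `Cc1ccc(NC(=O)NC(=O)c2ccc(OCc3ccc(Cl)cc3Cl)cc2)cc1-c1nc2ccccc2[nH]1` gives 12200 nM, the lowest of the three. Compound 4 `Cc1ccc(NC(=O)NC(=O)c2ccc(OCc3ccc(F)cc3)cc2)cc1-c1nc2ccccc2[nH]1` carries the change (4-fluorophenyl in place of 2,4-dichlorophenyl on a saturated chain carbon bound to an oxygen on an aromatic ring). The steps that touch this position are a 2.5-fold lower number from compound 1 to compound 3 (0.39 log units; beyond the scatter) and a 3.5-fold lower number from compound 2 to compound 3 (0.54 log units; beyond the scatter), while a 1.4-fold higher number from compound 1 to compound 2 (0.15 log units; within the scatter) shows little difference between the two dichloro patterns. Because compound 1, bearing a plain phenyl, stands at 30100 nM and compound 4 keeps only a single fluorine, a modest rise in this assay is expected. The expected step is a 1.8-fold higher number from compound 3 to compound 4 (0.26 log units; within the scatter). Compound 4 is therefore estimated at 22000 nM, within 9000 nM to 50000 nM.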

Compound 4, half-maximal inhibitory concentration: 35100 nM
Compound 4: middle estimate off by 1.6-fold (0.20 log units), on the low side; measured number inside the range.
By their numbers in this assay, from the lowest: compound 3; then compounds 1, 4 and 2 (each within the scatter of the next).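

Replacing the 2,4-dichlorophenyl with 4-fluorophenyl gives up what compound 3 had gained, with a 2.9-fold higher number from compound 3 to compound 4 (0.46 log units; beyond the scatter). The single fluorine leaves the plain phenyl result within the scatter, with a 1.2-fold higher number from compound 1 to compound 4 (0.07 log units; within the scatter), and compound 4 also lies within the scatter of the 2,3-dichlorophenyl compound, with a 1.2-fold lower number from compound 2 to compound 4 (0.08 log units; within the scatter), so only the 2,4-dichlorophenyl of compound 3 stands apart among these four groups. Nothing measured here gives a reason for this. A phenyl carrying one chlorine, or a methoxy or trifluoromethyl group on the phenyl, would show whether compound 3 needs both chlorines.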